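This account rests on a few compounds, and the source may have more. Where it says the series, first, only, none or still open, it means among the compounds named here.

Compound 1 `CCC(C)c1cc(/C=C/C(=O)c2ccc(Cl)cc2)cc2cc(C(C)=O)c(=O)oc12` was tested in a functional assay on A549 cells (Homo sapiens) for cytotoxicity, read by sulforhodamine B assay, with a stated time of 48 h (a lower number here means a stronger inhibitor, a higher number a weaker inhibitor), and compound 1 is reported there only as "not active" (no number reported), so no single number stands for it. A related compound, compound 2 `CCOC(=O)c1cc2cc(C=O)cc(C(C)CC)c2oc1=O`, gives 147000 nM in this assay, which is a weak effect. Compound 3 `CCOC(=O)c1cc2cc(/C=C/C(=O)c3ccc(Cl)cc3)cc(C(C)CC)c2oc1=O` differs from compound 1 by one change: ethoxy in place of methyl on a carbonyl carbon. Within the data shown here, no measured pair shows the effect of this change, so nothing beyond the usual scatter is expected in either direction, and compound 3 is expected to stay weak. The value of compound 3 in this assay is estimated at 100000 nM, within a range from 30000 nM to 300000 nM.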

Compound 3, half-maximal inhibitory concentration: 12900 nM
The estimate for compound 3 lay 7.8-fold (0.89 log units) above the measured number; measured number below the stated range.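

Among these compounds, compound 1 has no number in this assay, so no step from compound 1 to compound 3 can be read. Nothing measured here accounts for the result. As far as these compounds go, how far the change from acetyl to ethoxycarbonyl alone shifts activity stays open.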